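Adding a Second Methoxy to the Weakest Compound

The source may hold more compounds than are shown below. What is called first, only, known or untested is meant among the compounds shown, and "the series" means these compounds.

compound 1, `O=C(CCc1cccc2c1B(O)OC2)Nc1ccccc1`: 350 nM
compound 2, `COc1ccccc1NC(=O)CCc1cccc2c1B(O)OC2`: 430 nM
compound 3, `COc1cccc(-c2cccc(NC(=O)CCc3cccc4c3COB4O)c2)c1`: 46000 nM

In a functional assay on HCT-116 cells (Homo sapiens) for antiproliferative activity, read by MTT assay, with a stated time of 72 h (a lower number here means a stronger inhibitor, a higher number a weaker inhibitor), compound 1 gives 350 nM and compound 2 gives 430 nM. The change between them is methoxy in place of hydrogen on an aromatic carbon, and it produced a 1.2-fold higher number from compound 1 to compound 2 (0.09 log units; within the scatter). Compound 3 has a different core; how its core differs from that of compound 1 is not broken down here, and in this assay compound 3 gives 46000 nM. Compound 4, `COc1cc(OC)cc(-c2cccc(NC(=O)CCc3cccc4c3COB4O)c2)c1`, has not yet been measured. It differs from compound 3 by methoxy in place of hydrogen on an aromatic carbon. In compound 2 the entering group sits ortho to a large group, whereas in compound 4 it sits meta to a large group and meta to a methoxy group, so this is the same kind of change rather than the same one. Compound 4 is expected to show a 1.2-fold higher number from compound 3 to compound 4 (0.08 log units; within the scatter), resting on the small step of a 1.2-fold higher number from compound 1 to compound 2 (0.09 log units; within the scatter). Compound 4 is therefore estimated at 55000 nM, between 20000 nM and 150000 nM.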

Compound 4, half-maximal inhibitory concentration: 50000 nM
Compound 4: the middle estimate sits 1.1-fold (0.04 log units) above what was measured; low and high end bracket the measured number.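

Methoxy in place of hydrogen on an aromatic carbon gave a 1.1-fold higher number from compound 3 to compound 4 (0.04 log units; within the scatter) in this assay. Set beside the earlier step, the new one shows no difference between the two cores: the same change on two cores in this assay, a 1.2-fold higher number (0.09 log units; within the scatter) from compound 1 to compound 2 and a 1.1-fold higher number (0.04 log units; within the scatter) from compound 3 to compound 4, 1.1-fold (0.05 log units) apart, within the scatter of two such steps

Within the data shown here, both steps lie within the scatter, so the result shows only that this change did little on either core. It does not show that a change of real size would carry over in the same way, and two cores cannot speak for the whole series.

The compounds shown leave open whether an amine or a carboxylic acid in place of the methoxy would carry between these cores in the same way. As far as these compounds go, a longer chain, such as ethoxy, also remains open.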